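A few compounds are considered here, and "the series" means these few. Any claim that something is new, unique, unknown or untested is made for them only; others in the source may bear on it.

Compound 2 `COc1ccccc1-c1cc(CN(C)C)ccc1Cl` gives 1000 nM in an assay on isolated protein for binding affinity to 5-hydroxytryptamine receptor 3A (Homo sapiens) (a lower number here means a stronger inhibitor, a higher number a weaker inhibitor), and compound 1 `COc1ccccc1-c1cc(C2CCN(C)C2)ccc1Cl` gives 420 nM in this assay. Compound 2 stands as the higher of the two numbers, reached by the step of a 2.4-fold higher number from compound 1 to compound 2 (0.38 log units; beyond the scatter). Compound 3 `CCCCNCc1ccc(Cl)c(-c2ccccc2OC)c1` carries the change (butylamino in place of dimethylamino on a saturated chain carbon bound to an aromatic carbon). No measured step bears on this change; the only step shown, a 2.4-fold higher number from compound 1 to compound 2 (0.38 log units; beyond the scatter), concerns a different pair of groups. Compound 3 is therefore expected to stay close to compound 2, with the step of a 1.2-fold higher number from compound 2 to compound 3 (0.08 log units; within the scatter). The estimate for compound 3 in this assay is 1200 nM, from 400 nM to 3500 nM.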

Compound 3, inhibition constant: > 10000 nM
Compound 3: a limit, no number (the forecaster's own chance of this, stated with the estimate: 5%); middle value at least 8.3-fold (0.92 log units) away from the limit.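

In this assay, compound 3 gives a limit and not a number: the limit of > 10000 nM in this assay, at which 1 of the 3 values shown sits.

The group on this saturated chain carbon therefore matters more than the earlier pair suggested, with butylamino in place of dimethylamino giving an at least 10-fold higher number from compound 2 to compound 3 (1.00 log units; beyond the scatter). The wider change from 1-methylpyrrolidin-3-yl gives an at least 23-fold higher number from compound 1 to compound 3 (1.37 log units; beyond the scatter), larger than the modest 2.4-fold higher number from compound 1 to compound 2 (0.38 log units; beyond the scatter).

The compounds shown leave open whether the longer chain or the hydrogen-bond donor that butylamino brings goes with this drop. Methylamino and butyl(methyl)amino would separate the two, and the full size of the drop remains unknown.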